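Replacing nitro with methyl: expected cytotoxicity of compound 4

The source may hold more compounds than are shown below. What is called first, only, known or untested is meant among the compounds shown, and "the series" means these compounds.

Of the compounds shown here, three sharing one core have been tested in an ADME assay on NIH3T3 cells (Mus musculus) for cytotoxicity, read by XTT assay, with a stated time of 24 h; on this read-out higher numbers stand for weaker inhibition and lower numbers for stronger inhibition. Compound 1 `Cn1nnnc1SCC(=O)N/N=C/c1ccccc1[N+](=O)[O-]` gives 2020000 nM. Compound 2 `Cn1nnnc1SCC(=O)N/N=C/c1cccc([N+](=O)[O-])c1` gives 2000000 nM, a number indistinguishable from that of compound 1 within the usual scatter. Compound 3 `Cn1nnnc1SCC(=O)N/N=C/c1cccc(F)c1` gives 6320000 nM, and the step of a 3.2-fold higher number from compound 2 to compound 3 (0.50 log units; beyond the scatter) lies beyond the scatter. Compound 1 therefore sits together with compound 2, while compound 3 alone shows a higher number, meaning weaker inhibition.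

Compound 4 `Cc1ccccc1/C=N/NC(=O)CSc1nnnn1C` has not yet been measured. It differs from compound 1 by methyl in place of nitro on an aromatic carbon. Going by the values given here, no measured pair swaps nitro for methyl directly; the only step that bears on removing a nitro is a 3.2-fold higher number from compound 2 to compound 3 (0.50 log units; beyond the scatter), where fluoro took its place and the number rose modestly. Taking that step as the closest available guide, a modest rise in this assay is expected for compound 4, with wide uncertainty since the entering group is different. The estimate for compound 4 is 4000000 nM, with a range from 1500000 nM to 12000000 nM, which corresponds to an expected step of a 2.0-fold higher number from compound 1 to compound 4 (0.30 log units; within the scatter).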

Compound 4, half-maximal inhibitory concentration: 6320000 nM
For compound 4 the middle estimate is 1.6-fold (0.20 log units) below the measured one; the range from low to high includes it.
By their numbers in this assay, from the lowest: compounds 2 and 1 (each within the scatter of the next); then compounds 3 and 4 (each within the scatter of the next).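

In this assay, going by these compounds alone, the step of a 3.1-fold higher number from compound 1 to compound 4 (0.50 log units; beyond the scatter) is the first direct reading of a change at the aromatic carbon that carries the nitro group in compound 1, the place ortho to a large group. Together with a 3.2-fold higher number from compound 2 to compound 3 (0.50 log units; beyond the scatter), it means that both measured replacements of a nitro group raise the number, even though the entering groups and their places differ, and neither of the two pairs goes against this. Nothing measured here explains the rise.

From the compounds shown here alone, it remains open whether an amine or a carboxylic acid at this same carbon would also raise the number. It is equally unclear whether a longer chain, such as ethyl, would behave like methyl, so two replacements give only a narrow view of this position.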